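The compounds below may be only part of what the source reports. "The series", "measured", "known", "first", "only" and "open" are said of these compounds alone.

The measured compounds so far:

Compound 1, `O=C(CSc1nnc(Cc2ccccc2)n1-c1cccc(Cl)c1)NNC(=O)c1ccccc1O`. In an ADME assay on HCT-116 cells (Homo sapiens) for cytotoxicity (a lower number here means that less compound is tolerated, a higher number that more compound is tolerated), compound 1 gives > 20000 nM, which is a limit of the assay and not a number.

Compound 2, `COc1ccc(-n2c(Cc3ccccc3)nnc2SCC(=O)NNC(=O)c2ccccc2O)cc1`. In this assay compound 2 gives > 20000 nM, again a limit of the assay rather than a number.

Within the data shown here, compound 2 therefore stands only at a limit in this assay, and the single step measured so far, a step that the two limits leave unreadable from compound 1 to compound 2, cannot be read as a size in either direction. Among the measured compounds shown here, both values sit at the same limit, as summarised in the limit of > 20000 nM in this assay, at which 2 of the 2 values shown sit, so no measured step gives a readable size for how a change at this position moves the read-out.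

Compound 3, `O=C(CSc1nnc(Cc2ccccc2)n1C1CCCCC1)NNC(=O)c1ccccc1O`, differs from compound 2 by cyclohexyl in place of 4-methoxyphenyl on an aromatic nitrogen. For the measured compounds named here, no measured step bears on this change in a readable way, so there is no basis for expecting a step beyond the scatter in either direction in this assay. The most likely outcome for compound 3 is expected to be a further limit, and the step that the limit leaves unreadable from compound 2 to compound 3 is estimated to be flat. Compound 3 is accordingly expected to give about 25000 nM in this assay, within a range from 8000 nM to 80000 nM.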

Compound 3, half-maximal cytotoxic concentration: > 20000 nM
Compound 3 was reported as a limit; the forecaster's own chance of this, stated with the estimate: 75%; the middle value lies beyond the limit too.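

Compound 3 also stands at a limit in this assay, so its steps from compound 1 and from compound 2 cannot be read as a size in either direction: the limit of > 20000 nM in this assay, at which 3 of the 3 values shown sit. The compounds shown leave open where the half-maximal cytotoxic concentration of any of the three lies, and whether the group on the aromatic nitrogen moves the read-out at all.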